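Half-life notes: methoxyamino to amino

A few compounds are considered here, and "the series" means these few. Any claim that something is new, unique, unknown or untested is made for them only; others in the source may bear on it.

Measured in an in vivo ADME assay on the whole organism (strain Sprague-Dawley) for metabolic stability, with Rattus norvegicus as the target, at a dose of 5 mg/kg by the intravenous route; a higher number here means that the compound lasts longer, a lower number that the compound disappears faster:
- compound 1 `Cc1ccc(CNC2(CCC(C)(C)C)C(=O)C(C3=NS(=O)(=O)c4cc(NS(C)(=O)=O)ccc4N3)=C(O)c3ccccc32)cn1`: 0.5 h
- compound 2 `CON[C@]1(CCC(C)C)C(=O)C(C2=NS(=O)(=O)c3cc(NS(C)(=O)=O)ccc3N2)=C(O)c2ccccc21`: 0.6 h
- compound 3 `Cc1cccc(C)c1CN[C@]1(CCC(C)(C)C)C(=O)C(C2=NS(=O)(=O)c3cc(NS(C)(=O)=O)ccc3N2)=C(O)c2ccccc21`: 3.1 h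

Compound 2 at 0.6 h lies within the scatter of compound 1 and short of compound 3 by a gap beyond the scatter. Compound 4 `CC(C)CC[C@@]1(N)C(=O)C(C2=NS(=O)(=O)c3cc(NS(C)(=O)=O)ccc3N2)=C(O)c2ccccc21` comes from compound 2 through hydrogen in place of methoxy on an amine nitrogen (hydrogen in place of methoxy on an amine nitrogen, or methoxyamino to amino). Going by the values given here, no two measured compounds differ in one place only, so the series gives no direct measure of this change in this assay and the estimate stays anchored on compound 2 at 0.6 h with a wide range. The expected step of a 1.2-fold higher number from compound 2 to compound 4 (0.07 log units; within the scatter) is small and upward if anything, and it is expected to stay within the scatter. The half-life expected for compound 4 is 0.7 h in an estimated range of 0.3 h to 1.6 h for repeat measurements.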

Compound 4, half-life: 0.3 h
Beside the measured number, compound 4's estimate is 2.3-fold (0.37 log units) above it; the measured number falls inside the stated range.
By their numbers in this assay, from the lowest: compounds 4, 1 and 2 (each within the scatter of the next); then compound 3.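

In this assay, going by these compounds alone, the first single-place reading at this amine nitrogen is a 2.0-fold lower number from compound 2 to compound 4 (0.30 log units; within the scatter) and it stays within the scatter, so methoxyamino and amino are not separated here. On this evidence, the methoxy group on the amine nitrogen is not shown to matter for half-life, and the free amino form stays among the short-lived members of the series. No supporting data bear on why the step reads this way.

On these data alone, whether a methyl or acetyl group on this amine nitrogen would read apart from hydrogen and methoxy remains open. As far as these compounds go, it is also open whether methoxyamino to amino reads the same way in compounds carrying a longer chain elsewhere on the shared core.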